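The source may report more compounds than this note shows. Statements on the series, on what has been measured and on what is new or still open speak of the compounds shown alone.

Measured in an ADME assay on BJ cells (Homo sapiens) for cytotoxicity, with a stated time of 72 h; a lower number here means that less compound is needed, a higher number that more compound is needed for the effect:
- compound 1 `C=C[C@@](C)(/C=C/c1ccc(O)cc1)CCC1OC1(C)C`: > 36600 nM
- compound 2 `C=C[C@@](C)(/C=C/c1ccc(O)cc1)CC/C=C(C)/C=N/N`: > 36600 nM
- compound 3 `C=C[C@@](C)(/C=C/c1ccc(O)c(/C=C/C#N)c1)CCC=C(C)C`: > 36600 nM

Each entry is a limit and not a number. Among the measured compounds shown here, the series so far shows (the limit of > 36600 nM in this assay, at which 3 of the 3 values shown sit), so compound 3 has no rank among the others.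

Compound 4 `C=C[C@@](C)(/C=C/c1ccc(O)c(/C=C/c2ccc(F)cc2)c1)CCC=C(C)C` differs from compound 3 by 4-fluorophenyl in place of cyano on a double-bonded chain carbon bound to a double-bonded chain carbon.

For the measured compounds named here, the only measured step, a step that the two limits leave unreadable from compound 1 to compound 2, changes a different group and gives no size to carry over. No clear step in either direction is therefore expected in this assay, and the expected step is a step that the limit leaves unreadable from compound 3 to compound 4. For compound 4 the estimate is 40000 nM, with an expected range of 12000 nM to 90000 nM, and a further limit is the likeliest report.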

Compound 4, half-maximal effective concentration: > 36600 nM
Compound 4: only a limit was reported (the forecaster's own chance of this, stated with the estimate: 70%); the middle value does not contradict the limit.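

No step can be read from compound 3 to compound 4 in this assay, since both entries are limits and not numbers: the limit of > 36600 nM in this assay, at which 4 of the 4 values shown sit.

The compounds shown leave open whether any change on the shared core shifts this read-out at all.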